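A few compounds are considered here, and "the series" means these few. Any claim that something is new, unique, unknown or untested is made for them only; others in the source may bear on it.

Of the compounds shown here, three that share one core have been measured in a physicochemical assay for lipophilicity, measured as octanol-water partition; a higher number here means a more lipophilic compound, a lower number a more polar compound. Compound 1 `CCOc1ccc(/C=N/NC(=O)COc2cccc3ccccc23)cc1O` gives 3.82 in this assay. Compound 2 `O=C(COc1cccc2ccccc12)N/N=C/c1ccc(Cl)cc1` gives 4.54. Compound 3 `C/C(=N\NC(=O)COc1cccc2ccccc12)c1cccc([N+](=O)[O-])c1` gives 3.37, the lowest of the three numbers: compound 1 sits higher by a margin beyond the usual scatter, and compound 2 sits higher still, also beyond it. A fourth compound, compound 4 `C/C(=N\NC(=O)COc1cccc2ccccc12)c1ccc(C#N)cc1Br`, has not yet been measured. It differs from compound 3 in one place: 2-bromo-4-cyanophenyl in place of 3-nitrophenyl on a carbon with a double bond to nitrogen. For the measured compounds named here, no two measured compounds differ from each other in only one place, so nothing measured here shows directly how such an exchange moves the number. The step from compound 3 to compound 4 is expected to be an increase, moderate in size and beyond the scatter, estimated at a number 0.58 log units higher from compound 3 to compound 4 (beyond the scatter). On that basis the value of compound 4 in this assay is expected to come out near 3.95, within a range from 3.5 to 4.4.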

Compound 4, partition coefficient: 3.61
Compound 4: the middle estimate sits 0.34 log units above what was measured; the range from low to high includes it.
By their numbers in this assay, from the lowest: compounds 3, 4 and 1 (each within the scatter of the next, the first and the last beyond it); then compound 2.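

In this assay, for the compounds shown here, the exchange of 3-nitrophenyl for 2-bromo-4-cyanophenyl on a carbon with a double bond to nitrogen gives a number 0.24 log units higher from compound 3 to compound 4 (within the scatter) and is the first direct reading of a single change in this set. At this position, then, a phenyl ring carrying bromine and a nitrile cannot be told apart by this number from a phenyl ring carrying a nitro group. No measurement at hand explains this outcome.

Bromine and the nitrile enter together, so it remains open whether each alone would also leave the number within the scatter. Also open, as far as these compounds go, is how the number would respond at this position to a phenyl ring bearing an amine or a carboxylic acid, or to a longer chain in place of the ring.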